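The source may report more compounds than this note shows. Statements on the series, on what has been measured and on what is new or still open speak of the compounds shown alone.

Measured so far:
compound 1 `c1ccc2c(c1)CC2CN1CCN(c2cccc3c2OCCO3)CC1`, giving 214 nM
compound 2 `Clc1cccc2c1CC2CN1CCN(c2cccc3c2OCCO3)CC1`, giving 550 nM

Going by the values given here, in an assay on isolated protein for binding affinity to 5-hydroxytryptamine receptor 1B (Rattus norvegicus) (on this read-out lower numbers stand for stronger inhibition and higher numbers for weaker inhibition), compound 2 stands at the higher of the two numbers; its only neighbour is compound 1, and the step of a 2.6-fold higher number from compound 1 to compound 2 (0.41 log units; beyond the scatter) came with chloro in place of hydrogen on an aromatic carbon. Compound 3 `Fc1cccc2c1CC2CN1CCN(c2cccc3c2OCCO3)CC1` differs from compound 2 by fluoro in place of chloro on an aromatic carbon. Among the compounds with values here, only that one measured step bears on the change: adding the chloro weakened binding by a modest margin, so removing it should recover part of that loss, while the fluoro that enters is again a single heavy atom at the same place. The number for compound 3 is therefore expected to fall between the two measured values, closer to compound 2, with the estimated step of a 1.6-fold lower number from compound 2 to compound 3 (0.20 log units; within the scatter). Compound 3 is estimated at 350 nM, with a range from 160 nM to 750 nM.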

Compound 3, inhibition constant: 316 nM
Compound 3: middle estimate off by 1.1-fold (0.04 log units), on the high side, and the stated range covers the measured number.
By their numbers in this assay, from the lowest: compounds 1, 3 and 2 (each within the scatter of the next, the first and the last beyond it).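

In this assay, fluoro in place of chloro gives a 1.7-fold lower number from compound 2 to compound 3 (0.24 log units; within the scatter), and fluoro in place of hydrogen gives a 1.5-fold higher number from compound 1 to compound 3 (0.17 log units; within the scatter), so compound 3 cannot be told apart from either neighbour, even though those two neighbours differ beyond the scatter. At this place on the aromatic ring, a halogen therefore does not always carry a step beyond the scatter: of the two halogens shown, only the chloro does so. Nothing at hand explains why the fluoro and the chloro read differently here.

The compounds shown leave open how a bromo, a methyl or a methoxy at this same place would read. They also leave open whether a fluoro or a chloro on another aromatic carbon of that ring would give similar steps.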